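The source may report more compounds than this note shows. Statements on the series, on what has been measured and on what is new or still open speak of the compounds shown alone.

Measured so far: compound 1 `Clc1ccc(/C=N/c2nnc(SCc3c[se]c(-c4ccccc4)n3)s2)cc1` gives 50000 nM in a functional assay on L1210 cells (Mus musculus) for antiproliferative activity, read by CCK-8 assay; on this read-out lower numbers stand for stronger inhibition and higher numbers for weaker inhibition; compound 2 `Brc1ccc(/C=N/c2nnc(SCc3c[se]c(-c4ccccc4)n3)s2)cc1` gives 46500 nM in this assay. Compound 3 `COc1cc(/C=N/c2nnc(SCc3c[se]c(-c4ccccc4)n3)s2)ccc1O` reaches only a limit of this assay, > 100000 nM.

As far as these compounds go, compound 3 thus sits at the limit of > 100000 nM in this assay, at which 1 of the 3 values shown sits, so its true number is unknown; the bromo for chloro change gave a 1.1-fold lower number from compound 1 to compound 2 (0.03 log units; within the scatter). Compound 4 `O=[N+]([O-])c1ccc(/C=N/c2nnc(SCc3c[se]c(-c4ccccc4)n3)s2)cc1` carries 4-nitrophenyl in place of 4-hydroxy-3-methoxyphenyl on a carbon with a double bond to nitrogen. For the measured compounds named here, the steps that bear on this change run the opposite way: an at least 2.0-fold higher number from compound 1 to compound 3 (0.30 log units; that floor lies within the scatter) and an at least 2.1-fold higher number from compound 2 to compound 3 (0.33 log units; beyond the scatter), each a move from a halophenyl to the hydroxy-methoxyphenyl with a higher number. Exchanging that group for a nitrophenyl is expected to bring the number back roughly to where compound 1 and compound 2 stand, though it may again end at the limit. Compound 4 is expected at 50000 nM, between 15000 nM and 150000 nM. The expected step is an at least 2.0-fold lower number from compound 3 to compound 4 (0.30 log units; that floor lies within the scatter).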

Compound 4, half-maximal inhibitory concentration: > 100000 nM
Compound 4 gave a limit, no number; the forecaster's own chance of this, stated with the estimate: 30%; middle value at least 2.0-fold (0.30 log units) from the limit.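

In this assay, nitro in place of bromo on an aromatic carbon gives an at least 2.1-fold higher number from compound 2 to compound 4 (0.33 log units; beyond the scatter), and nitro in place of chloro gives an at least 2.0-fold higher number from compound 1 to compound 4 (0.30 log units; that floor lies within the scatter). So a 4-nitrophenyl does not restore a readable number at this carbon with a double bond to nitrogen, and of the groups shown only 4-chlorophenyl and 4-bromophenyl give one. Compound 4 joins compound 3 at a limit rather than a number: the limit of > 100000 nM in this assay, at which 2 of the 4 values shown sit.

The step from compound 3 to compound 4 cannot be read, as both values are limits. As far as these compounds go, whether an amine or a carboxylic acid in place of the nitro would give a readable number stays open.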